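The compounds below may be only part of what the source reports. "The series", "measured", "known", "first", "only" and "open" are said of these compounds alone.

Compound 1 `CCC(COC)Nc1nc(C)nc2c1nnn2-c1c(C)cc(C)cc1C`: 59.4 nM
Compound 2 `CCCC(CCC)Nc1nc(C)nc2c1nnn2-c1c(C)cc(C)cc1C`: 4 nM
Compound 3 `COCC(COC)N(C)c1nc(C)nc2c1nnn2-c1ccc(C(C)C)cc1Br`: 21.3 nM

In an in vitro assay on 293-EBNA cells for binding affinity to corticotropin-releasing factor receptor 1 (Homo sapiens) (on this read-out higher numbers stand for weaker inhibition and lower numbers for stronger inhibition), compound 3 stands second highest of the three numbers, sitting between compound 1 and compound 2. Compound 4 `COCCCNc1nc(C)nc2c1nnn2-c1ccc(C(C)C)cc1Br` differs from compound 3 by a group of 6 heavy atoms (4 carbon, 1 nitrogen, 1 oxygen; no ring) in place of a group of 9 heavy atoms (6 carbon, 1 nitrogen, 2 oxygen; no ring), on an aromatic carbon. Among the measured compounds shown here, only one measured step exists, a 15-fold lower number from compound 1 to compound 2 (1.17 log units; beyond the scatter), and it concerns a different side chain swap on a different core, so it bears only loosely on the present change. Among the compounds shown, the one with a methoxy-bearing side chain and a free amine hydrogen, compound 1, gives the weakest number. A modestly higher number is therefore expected for compound 4, a step of a 2.3-fold higher number from compound 3 to compound 4 (0.37 log units; beyond the scatter), giving an estimate of 50 nM with a range from 12 nM to 200 nM.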

Compound 4, inhibition constant: 291 nM
Estimate against measurement, compound 4: 5.8-fold (0.76 log units) below, outside the stated range (above it).
By their numbers in this assay, from the lowest: compound 2; then compound 3; then compound 1; then compound 4.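

In this assay, putting (3-methoxypropyl)amino on this aromatic carbon in place of the larger group of 9 heavy atoms gives a 14-fold higher number from compound 3 to compound 4 (1.14 log units; beyond the scatter). The group at this position therefore matters strongly on this core as well, not only in a 15-fold lower number from compound 1 to compound 2 (1.17 log units; beyond the scatter), where the core differs. The entering group carries one hydrogen-bond donor where the leaving group has none, but no measurement here explains the rise.

Going by these compounds, it remains open whether the size of the group, its branching or the hydrogen on its nitrogen drives the step. An N-methyl-(3-methoxypropyl)amino group would separate the effect of that hydrogen from the rest of the change.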